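A few compounds are considered here, and "the series" means these few. Any claim that something is new, unique, unknown or untested is made for them only; others in the source may bear on it.

Series notes, ester variation on the shared core.

Three compounds have numbers in an assay on membranes from HEK293 cells for displacement of a labelled ligand from adenosine receptor A2b (Homo sapiens), read by scintillation counting, with a stated time of 30 min, tested at 1 uM; a lower number here means less inhibition, a higher number more inhibition at the concentration tested (going by the name of the read-out). Compound 1 `CC1=C(C(=O)OCc2ccccc2)C(c2ccoc2)NC(=S)N1` gives 36%. Compound 2 `CCCOC(=O)C1=C(C)NC(=S)NC1c1cccs1` gives 3%. Compound 3 `CC1=C(C(=O)OC(C)(C)C)C(c2cccs2)NC(=S)N1` gives 26%. Among the measured compounds shown here, the one step between compounds differing in a single place is a number 23 percentage points higher from compound 2 to compound 3 (beyond the scatter), the tert-butyl ester standing above the propyl ester beyond the scatter.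

Compound 3 stands second highest of the three numbers; its nearest neighbour is compound 1, whose number is higher by an amount within the scatter, and its furthest is compound 2, lower by an amount beyond the scatter.

Compound 4 `CC1=C(C(=O)OCc2ccccc2)C(c2cccs2)NC(=S)N1` is the next point. The change from compound 3 is benzyl in place of tert-butyl on an oxygen next to a carbonyl group. The step from compound 2 to compound 3 is the only measured one at the same place, and it shows that the ester group moves this assay by a modest amount. Compound 1 carries the benzyl ester already, though on a different five-membered ring, and its number of 36% sits within the scatter of compound 3. On that basis no step beyond the scatter is expected from the benzyl ester, a number 7 percentage points higher from compound 3 to compound 4 (within the scatter). Compound 4 is therefore estimated at 33%, with a range from 18% to 50%.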

Compound 4, a percentage reported as inhibition, at one concentration (the size of the read-out at that concentration, not a potency): 45%
Beside the measured number, compound 4's estimate is 12 percentage points below it; the range from low to high includes it.
By their numbers in this assay, from the lowest: compound 2; then compounds 3, 1 and 4 (each within the scatter of the next, the first and the last beyond it).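

In this assay the ester position on the thiophen-2-yl compounds now carries three groups, and benzyl on the oxygen next to a carbonyl group gives the top number of those three: a number 19 percentage points higher from compound 3 to compound 4 (beyond the scatter) and a number 42 percentage points higher from compound 2 to compound 4 (beyond the scatter) add to the earlier step, a number 23 percentage points higher from compound 2 to compound 3 (beyond the scatter) and so propyl, tert-butyl and benzyl stand in a rising order with each step beyond the scatter. Among the compounds shown here, the change at the saturated ring carbon is read for the first time, and with the benzyl ester held fixed, thiophen-2-yl in place of furan-3-yl gives a number 9 percentage points higher from compound 1 to compound 4 (within the scatter) so that this pair shows the ring exchange leaving the number within the scatter, while the ester exchange does not. Nothing at hand accounts for the differences between the esters.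

The compounds shown leave open whether the rise with benzyl goes with its aromatic ring or with its larger count of heavy atoms, a question that a cyclohexylmethyl ester or a phenethyl ester would address. They also leave open whether the furan-3-yl and thiophen-2-yl rings stay within the scatter of each other when the ester is propyl or tert-butyl.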